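The compounds below may be only part of what the source reports. "The series", "measured", "known", "first", "only" and "open" are said of these compounds alone.

Compound 2 `COc1ccc(CN(C(=O)CSC(=S)N2CCN(C(=O)OC(C)(C)C)CC2)c2cc(OC)c(OC)c(OC)c2)cc1` is the reference point here. In a functional assay on MGC-803 cells (Homo sapiens) for inhibition, read by CCK-8 assay, with a stated time of 48 h (a lower number here means a stronger inhibitor, a higher number a weaker inhibitor), compound 2 gives 310 nM. Compound 1 `COc1ccc(CN(C(=O)CSC(=S)N2CCN(C(C)=O)CC2)c2cc(OC)c(OC)c(OC)c2)cc1`, which differs only in the group on the carbonyl carbon, gives 480 nM; the step of a 1.5-fold lower number from compound 1 to compound 2 (0.19 log units; within the scatter) is within the scatter, so the two sit together, and no third number stands apart from them. Compound 3 `COc1ccc(CN(C(=O)CSC(=S)N2CCN(C(=O)OC(C)(C)C)CC2)c2ccc(OC)cc2)cc1` returns only a limit, > 20000 nM. That is the limit of > 20000 nM in this assay, at which 1 of the 3 values shown sits. The step of an at least 64-fold higher number from compound 2 to compound 3 (1.80 log units; beyond the scatter) shows that the 3,4,5-trimethoxyphenyl on the amide-type nitrogen matters greatly.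

Compound 4 `COc1ccc(CN(C(=O)CSC(=S)N2CCN(C(=O)OC(C)(C)C)CC2)c2cc(OC)c(OC)c(OC)c2)cc1Br` keeps that ring and changes a different part: bromo in place of hydrogen on an aromatic carbon. Neither measured step touches this ring, so nothing observed so far speaks to a bromo placed there, and no change beyond the scatter is expected in this assay. The estimate for compound 4 is therefore close to compound 2, namely 350 nM, expected to fall between 120 nM and 1200 nM, which corresponds to an expected step of a 1.1-fold higher number from compound 2 to compound 4 (0.05 log units; within the scatter).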

Compound 4, half-maximal inhibitory concentration: 3710 nM
Compound 4: middle estimate off by 11-fold (1.03 log units), on the low side; the measured number lies above the stated range.
By their numbers in this assay, from the lowest: compounds 2 and 1 (each within the scatter of the next); then compound 4. At a limit, above all of these: compound 3.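

In this assay, the 4-methoxybenzyl group proves sensitive to change: the step of a 12-fold higher number from compound 2 to compound 4 (1.08 log units; beyond the scatter) shows that one bromo on this ring, ortho to a methoxy group, clearly weakens inhibition. Going by these compounds alone, the earlier steps changed only the group on the carbonyl carbon and the aromatic ring on the amide-type nitrogen, so they said nothing about this second ring, and this is the first sign that it matters too. Nothing measured here explains why the bromo has this effect.

Still open, as far as these compounds go, is whether any replacement of this hydrogen weakens inhibition, or whether a fluoro, a methyl or an amine in the same place would leave the number close to that of compound 2. From the compounds shown here alone, it is also open whether a bromo on another carbon of this ring would have the same effect.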